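The source may report more compounds than this note shows. Statements on the series, on what has been measured and on what is new or still open speak of the compounds shown alone.

Measured so far in an assay for binding affinity, read by spectrophotometry; a lower number here means a stronger inhibitor, a higher number a weaker inhibitor:
- compound 1 `C[C@H](CCCN1CCCC1)Nc1ccnc2cc(Cl)ccc12` gives 140000 nM
- compound 2 `C[C@@H](CCCN1CCN(C)CC1)Nc1ccnc2cc(Cl)ccc12` gives 140000 nM
- compound 3 `C[C@H](CCCN1CCN(C)CC1)Nc1ccnc2cc(Cl)ccc12` gives 180000 nM

Compound 3 carries the highest of the three numbers, yet both neighbours lie within the scatter of it. The ring swap from compound 1 to compound 3 gave a 1.3-fold higher number from compound 1 to compound 3 (0.11 log units; within the scatter), and the configuration change recorded as a 1.3-fold higher number from compound 2 to compound 3 (0.11 log units; within the scatter) is read in the light of the fact that compounds 2 and 3 differ only in the configuration as drawn. Compound 4 `C[C@H](CCCN1CCCCC1)Nc1ccnc2cc(Cl)ccc12` is the next member, differing from compound 3 by piperidin-1-yl in place of 4-methylpiperazin-1-yl on a saturated chain carbon, four bonds along the chain from a nitrogen on an aromatic ring. Going by the values given here, the only bearing step is the earlier amine-ring exchange, which stayed within the scatter; the step to compound 4 is therefore expected to be a 1.2-fold lower number from compound 3 to compound 4 (0.08 log units; within the scatter), with no direction beyond the scatter. Compound 4 is estimated at 150000 nM, within 60000 nM to 400000 nM.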

Compound 4, half-maximal inhibitory concentration: 130000 nM
The estimate for compound 4 lay 1.2-fold (0.06 log units) above the measured number; the range from low to high includes it.
By their numbers in this assay, from the lowest: compounds 4, 1, 2 and 3 (each within the scatter of the next).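

In this assay, the exchange of 4-methylpiperazin-1-yl for piperidin-1-yl on a saturated chain carbon gives a 1.4-fold lower number from compound 3 to compound 4 (0.14 log units; within the scatter), and the exchange of pyrrolidin-1-yl for piperidin-1-yl gives a 1.1-fold lower number from compound 1 to compound 4 (0.03 log units; within the scatter). All three rings at this position therefore read alike, and going from two ring hetero atoms to one shows no readable effect here. Nothing available bears on why these numbers stay together.

Still open, from the compounds shown here alone, is whether a morpholin-4-yl ring, an open-chain dimethylamino group or a carboxylic acid at this position would leave the scatter. Going by these compounds, a longer chain between the ring and the core is equally open.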